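Acyloxymethyl phosphonate esters: half-life in human blood

The compounds below may be only part of what the source reports. "The series", "measured", "known", "first", "only" and "open" are said of these compounds alone.

The series shares the core of compound 1 `COC(=O)CCNC(=O)[C@@H]1O[P@](=O)(OCOC(=O)c2scnc2C)OCC1(C)C`, in which the acyloxymethyl carrier bears a heteroaryl carbonyl. In an ADME assay on blood (Homo sapiens) for pharmacokinetics (on this read-out higher numbers stand for a longer-lived compound and lower numbers for a shorter-lived compound), compound 1 gives < 0.16 h, a limit of the assay and not a number. Compound 2 `CCc1cc(C(=O)OCO[P@]2(=O)OCC(C)(C)[C@H](C(=O)NCCC(=O)OC)O2)n(C)n1` differs by the heteroaryl group. In this assay compound 2 gives < 0.16 h, again a limit of the assay. The step that the two limits leave unreadable from compound 1 to compound 2 is therefore unreadable, and compound 2 stands only at a limit, as the limit of < 0.16 h in this assay, at which 2 of the 2 values shown sit, records.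

Compound 3 `COC(=O)CCNC(=O)[C@@H]1O[P@](=O)(OCOC(=O)c2cc(C(C)(C)C)n[nH]2)OCC1(C)C` carries the change (3-(tert-butyl)-1H-pyrazol-5-yl in place of 3-ethyl-1-methyl-1H-pyrazol-5-yl on a carbonyl carbon). For the measured compounds named here, no measured step reads on this change, since the only step in this assay is unreadable. With both values sitting at the limit, a further value at the limit is expected, and the step that the limit leaves unreadable from compound 2 to compound 3 is estimated to lie within the scatter. For compound 3 the expected value in this assay is 0.1 h, with a range from 0.04 h to 0.3 h.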

Compound 3, half-life: < 0.16 h
Compound 3: a limit, no number; the forecaster's own chance of this, stated with the estimate: 80%; the middle value is on the limit's open side.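

No step among compound 1, compound 2 and compound 3 can be read in this assay, as all three sit at the same limit: the limit of < 0.16 h in this assay, at which 3 of the 3 values shown sit.

The compounds shown leave open whether any heteroaryl group on the carbonyl carbon gives a readable half-life, and how these three compare.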